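The source may hold more compounds than are shown below. What is called first, only, known or untested is meant among the compounds shown, and "the series" means these compounds.

Three compounds share one core and differ only in the group on the aryl ether ring. Compound 1 `Cc1nn(C)c(Oc2ccc(Cl)cc2)c1/C=N\OCc1c(Cl)c(-c2ccc(F)cc2)nn1C` gives 6030 nM in a functional assay on HCT-116 cells (Homo sapiens) for antiproliferative activity, read by MTT assay, with a stated time of 72 h; a higher number here means a weaker inhibitor, a lower number a stronger inhibitor; compound 2 `Cc1ccc(Oc2c(/C=N\OCc3c(Cl)c(-c4ccc(F)cc4)nn3C)c(C)nn2C)cc1` gives 2910 nM; compound 3 `Cc1nn(C)c(Oc2ccc(OC(F)(F)F)cc2)c1/C=N\OCc1c(Cl)c(-c2ccc(F)cc2)nn1C` gives 2310 nM. Compound 2 thus sits between the other two: a 2.1-fold lower number from compound 1 to compound 2 (0.32 log units; beyond the scatter), while the gap to compound 3 stays inside the scatter. Compound 4 `Cc1ccc(Oc2c(/C=N\OCc3c(Cl)c(-c4ccc(Cl)cc4)nn3C)c(C)nn2C)cc1` differs from compound 2 by chloro in place of fluoro on an aromatic carbon. Among the compounds with values here, no measured step touches that ring, so nothing here sets the size of this change directly; the closest case, swapping small groups on the other ring, gave a 1.3-fold lower number from compound 2 to compound 3 (0.10 log units; within the scatter), which lay inside the scatter. The step from compound 2 to compound 4 is therefore expected to be small, a 1.2-fold lower number from compound 2 to compound 4 (0.07 log units; within the scatter). For compound 4 the estimate in this assay is 2500 nM, within 1000 nM to 6500 nM.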

Compound 4, half-maximal inhibitory concentration: 2850 nM
Compound 4: middle estimate off by 1.1-fold (0.06 log units), on the low side; the measured number falls inside the stated range.
By their numbers in this assay, from the lowest: compounds 3, 4 and 2 (each within the scatter of the next); then compound 1.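

The change from 4-fluorophenyl to 4-chlorophenyl gives a 1.0-fold lower number from compound 2 to compound 4 (0.01 log units; within the scatter) in this assay, so the two halogens cannot be told apart here. Within the data shown here, this is the first measured change on this ring, which stayed 4-fluorophenyl in compounds 1, 2 and 3, and it shows only that this one swap leaves the number within the scatter. No supporting measurement speaks to the reason for this result.

Still open, going by these compounds, is how an amine, a carboxylic acid or a longer chain would read at this position. Also open, on these data alone, is whether the swap would read the same with chloro or trifluoromethoxy on the aryl ether ring.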